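Branching the Ketone Chain in a Glutamate Receptor Modulator

This account rests on a few compounds, and the source may have more. Where it says the series, first, only, none or still open, it means among the compounds named here.

Within the data shown here, compound 1 `CCCC(=O)c1ccc(OCCCCOc2ccc(F)c(C(=O)O)c2)c(C)c1O` was tested in an assay on HEK293 cells for positive allosteric modulation of metabotropic glutamate receptor 2 (Rattus norvegicus), read by thallium flux, with a stated time of 2.5 min (on this read-out lower numbers stand for an effect already at smaller amounts and higher numbers for an effect only at larger amounts of compound), and gives 74 nM, the lowest of the two numbers measured so far. Compound 2 `Cc1cc(C(=O)O)ccc1OCCCCOc1ccc(C(=O)C(C)C)c(O)c1C` gives 234 nM in this assay, a number beyond the usual scatter above that of compound 1, but the two differ in several places, so no single change can be credited for the gap. Compound 3 `Cc1c(OCCCCOc2ccc(F)c(C(=O)O)c2)ccc(C(=O)C(C)C)c1O` differs from compound 1 in one place only: isopropyl in place of propyl on a carbonyl carbon. Among the measured compounds shown here, no measured pair isolates this change, so only a modest step is expected, more likely toward a higher number, as a 1.5-fold higher number from compound 1 to compound 3 (0.17 log units; within the scatter). Compound 3 is therefore expected to give about 110 nM, within 50 nM to 250 nM.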

Compound 3, half-maximal effective concentration: 171 nM
For compound 3 the middle estimate is 1.6-fold (0.19 log units) below the measured one; low and high end bracket the measured number.
By their numbers in this assay, from the lowest: compound 1; then compounds 3 and 2 (each within the scatter of the next).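

Swapping propyl for isopropyl on a carbonyl carbon keeps the same atoms and changes only how they are joined, yet in this assay it gives a 2.3-fold higher number from compound 1 to compound 3 (0.36 log units; beyond the scatter). This position therefore responds to branching of the chain, and within this pair the unbranched propyl gives the lower number. Nothing available explains this step.

On these data alone, it remains open whether a longer chain such as butyl, or a cyclopropyl group, on the same carbonyl carbon would lower or raise the number. As far as these compounds go, it is also open whether the same swap would have a similar effect on the core of compound 2.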